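The source may report more compounds than this note shows. Statements on the series, on what has been measured and on what is new or still open speak of the compounds shown alone.

Compound 1 `Cc1ccc(S(=O)(=O)N(Cc2cccc(F)c2F)Cc2cn(S(=O)(=O)c3ccc(C)cc3)c3ccccc23)cc1`: -13.9%; compound 2 `Cc1ccc(S(=O)(=O)N(Cc2cn(Cc3ccc(F)cc3F)nn2)Cc2cn(S(=O)(=O)c3ccc(C)cc3)c3ccccc23)cc1`: 12.3%; compound 3 `COc1ccc(Cn2cc(CN(Cc3cn(S(=O)(=O)c4ccc(C)cc4)c4ccccc34)S(=O)(=O)c3ccc(C)cc3)nn2)c(OC)c1`: 7.6%.

In a functional assay on 3T3-L1 cells (Mus musculus) for inhibition, with a stated time of 20 min, tested at 20 uM (a lower number here means less inhibition, a higher number more inhibition at the concentration tested (going by the name of the read-out)), compound 1 gives -13.9%, the lowest of the three numbers; compound 3 lies higher by a gap beyond the scatter, and compound 2 higher still. Going by the values given here, the one measured step, a number 4.7 percentage points lower from compound 2 to compound 3 (within the scatter), concerns the group on the saturated chain carbon bound to an aromatic nitrogen and does not touch the amine nitrogen. Compound 4 `Cc1ccc(S(=O)(=O)n2cc(CNCc3cccc(F)c3F)c3ccccc32)cc1` differs from compound 1 by hydrogen in place of (4-methylphenyl)sulfonyl on an amine nitrogen. Among the compounds with values here, no measured step bears on this change, so the expectation rests on compound 1 alone. Compound 4 is expected to show -6% in this assay, within -30% to 20%. The expected step of a number 7.9 percentage points higher from compound 1 to compound 4 (within the scatter) is within the scatter.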

Compound 4, a percentage reported as inhibition, at one concentration (the size of the read-out at that concentration, not a potency): 46%
The estimate for compound 4 lay 52 percentage points below the measured number; measured number outside the range, above it.
By their numbers in this assay, from the lowest: compound 1; then compounds 3 and 2 (each within the scatter of the next); then compound 4.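

In this assay, hydrogen in place of (4-methylphenyl)sulfonyl on the amine nitrogen gives a number 59.9 percentage points higher from compound 1 to compound 4 (beyond the scatter). This makes the amine nitrogen the first position here where a single change moves the number beyond the scatter, and the sulfonyl group there is not needed for the inhibition seen. Nothing available accounts for the rise.

On these data alone, whether a methyl or acetyl group on that nitrogen would hold the number of compound 4 stays open. So does whether hydrogen there would raise the numbers of compound 2 and compound 3 in the same way.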